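The compounds below may be only part of what the source reports. "The series", "measured", "known", "first", "only" and "open" are said of these compounds alone.

This study follows a short series built on one shared core and asks how much of each compound cells tolerate over a week. an ADME assay on BCBL1 cells (Homo sapiens) for cytotoxicity, with a stated time of 7 days (a lower number here means that less compound is tolerated, a higher number that more compound is tolerated), supplies the read-out as a half-maximal cytotoxic concentration. Compound 1, `Nc1nc2c(ncn2/C=C2/CC2(CO)CO)c(=O)[nH]1`, is the parent of the series. In this assay compound 1 reaches only > 20000 nM, which is a limit of the assay rather than a number. Compound 2, `CCCCCCCCSc1nc(N)nc2c1ncn2/C=C1/CC1(CO)CO`, carries an octylsulfanyl group on the same core. In this assay compound 2 likewise stops at > 20000 nM, again a limit and not a number. For the measured compounds named here, compound 2 thus stands at the limit of > 20000 nM in this assay, at which 2 of the 2 values shown sit, so neither measured compound can be placed above or below the other, and no step between them is known. Compound 3, `CNc1nc(N)nc2c1ncn2/C=C1/CC1(CO)CO`, has not yet been measured; it differs from compound 2 by methylamino in place of octylsulfanyl on an aromatic carbon. With nothing in the two measured values pointing either way, the expected step is a step that the limit leaves unreadable from compound 2 to compound 3, that is, none beyond the scatter. Compound 3 is therefore estimated at 25000 nM, within a range from 12000 nM to 60000 nM, and most likely reported once more as a limit.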

Compound 3, half-maximal cytotoxic concentration: 67000 nM
Estimate against measurement, compound 3: 2.7-fold (0.43 log units) below, outside the stated range (above it).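

Compound 3 gives a number, but compound 2 gives only a limit of the assay, so no step between compound 2 and compound 3 can be read in this assay: the limit of > 20000 nM in this assay, at which 2 of the 3 values shown sit.

The compounds shown leave open whether methylamino in place of octylsulfanyl changes how much compound the cells tolerate, and in which direction.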